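Shortening the ester acyl chain of compound 2

This account rests on a few compounds, and the source may have more. Where it says the series, first, only, none or still open, it means among the compounds named here.

In a functional assay on K562 cells (Homo sapiens) for inhibition, read by MTT assay, with a stated time of 48 h (on this read-out higher numbers stand for weaker inhibition and lower numbers for stronger inhibition), compound 1 `Cc1cc2c(cc1C(=O)c1ccc(C(=O)OCCCOC(=O)c3ccc(C(=O)Nc4ccc5c(c4)C(C)(C)CCC5(C)C)cc3)cc1)C(C)(C)CCC2(C)C` gives 49100 nM. Compound 2 `CCCC(CCC)C(=O)OCCCOC(=O)c1ccc(C(=O)Nc2ccc3c(c2)C(C)(C)CCC3(C)C)cc1` is reported in this assay only as > 1000000 nM, which is a limit of the assay and not a number. One of the two values shown sits there: the limit of > 1000000 nM in this assay, at which 1 of the 2 values shown sits. Compound 3 `CCCC(=O)OCCCOC(=O)c1ccc(C(=O)Nc2ccc3c(c2)C(C)(C)CCC3(C)C)cc1` differs from compound 2 by propyl in place of 1-propylbutyl on a carbonyl carbon. Since compound 2 is known only as a limit, no measured step size is available. Compound 3 is expected to remain near that limit, with an expected step of an at least 1.1-fold lower number from compound 2 to compound 3 (0.04 log units; that floor lies within the scatter) of no more than the scatter. Compound 3 is estimated at 900000 nM, within 200000 nM to 4000000 nM.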

Compound 3, half-maximal inhibitory concentration: 4570 nM
Beside the measured number, compound 3's estimate is 200-fold (2.29 log units) above it; measured number below the stated range.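

Compound 2 is reported only as a limit of the assay, > 1000000 nM. In this assay, propyl in place of 1-propylbutyl on the carbonyl carbon gives an at least 210-fold lower number from compound 2 to compound 3 (2.34 log units; beyond the scatter), so the read-out responds strongly to what this carbonyl carbon carries. The size of this step is itself a bound and not a measured distance: the limit of > 1000000 nM in this assay, at which 1 of the 3 values shown sits.

The compounds shown leave open whether the number keeps falling with an ethyl or methyl group on this carbonyl carbon, and how a straight pentyl chain or an amine would read there. They also give no reason for the change.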